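Fixing the stereocentre of compound 1

The source may report more compounds than this note shows. Statements on the series, on what has been measured and on what is new or still open speak of the compounds shown alone.

Going by the values given here, in a functional assay on DU-145 cells (Homo sapiens) for antiproliferative activity, with a stated time of 48 h (a higher number here means a weaker inhibitor, a lower number a stronger inhibitor), compound 1 `Cc1cc(=O)c2c(O)cc(OCC3CO3)cc2o1` gives 20900 nM, the higher of the two numbers measured so far, and compound 2 `Cc1cc(=O)c2c(OCC3CO3)cc(OCC3CO3)cc2o1` gives 7300 nM. Compound 3 `Cc1cc(=O)c2c(O)cc(OC[C@H]3CO3)cc2o1` has the same atoms and bonds as compound 1: the two compounds have the same atoms and bonds; at least one stereo element is drawn with a configuration in one of them and without one in the other: 1 of 1 stereo elements differ; a stereocentre at a saturated ring carbon is drawn without a configuration in compound 1 and R in compound 3. Among the compounds with values here, the only measured step, a 2.9-fold lower number from compound 1 to compound 2 (0.46 log units; beyond the scatter), is modest and comes from (oxiran-2-yl)methyl in place of hydrogen on an oxygen on an aromatic ring. That is a change of atoms, not of stereo configuration, so it bears on the present change only loosely. Within the data shown here, no measured pair isolates a stereocentre, so no step beyond the scatter is expected in this assay. The estimated step, a 1.0-fold lower number from compound 1 to compound 3 (0.02 log units; within the scatter), is correspondingly small. Compound 3 is expected at 20000 nM, with an estimated range of 10000 nM to 42000 nM.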

Compound 3, half-maximal inhibitory concentration: 15200 nM
The estimate for compound 3 lay 1.3-fold (0.12 log units) above the measured number; the measured number falls inside the stated range.
By their numbers in this assay, from the lowest: compound 2; then compounds 3 and 1 (each within the scatter of the next).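

In this assay, drawing the stereocentre at the saturated ring carbon as R rather than without a configuration comes with a 1.4-fold lower number from compound 1 to compound 3 (0.14 log units; within the scatter), so no effect of this change can be told from the scatter. Going by these compounds alone, this pair is the first to isolate the stereocentre, and a 2.9-fold lower number from compound 1 to compound 2 (0.46 log units; beyond the scatter) remains the only step beyond the scatter, a change of atoms rather than of configuration. The comparison sets a defined drawing against an undefined one, not one configuration against its opposite: the fact that one of compounds 1 and 3 is drawn with a defined configuration and the other without, at the place where they differ

On these data alone, how the S configuration at this carbon would read against compound 3 remains open. Also open, as far as these compounds go, is how the series would respond to an amine, a carboxylic acid or a longer chain in place of the (oxiran-2-yl)methyl group.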